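The source may hold more compounds than are shown below. What is called first, only, known or untested is meant among the compounds shown, and "the series" means these compounds.

Working notes on the series. Compound 1 `CC1=C(C(=O)OCc2ccccc2)C(c2ccoc2)NC(=S)N1` and compound 2 `CC1=C(C(=O)OCc2ccccc2)C(c2cccs2)NC(=S)N1` share one core; compound 3 `CC1=C(c2ncc(C)o2)C(c2ccoc2)NC(=O)N1` and compound 4 `CC1=C(c2ncc(C)o2)C(c2cccs2)NC(=O)N1` share another. The difference between the two cores is not broken down here. In an assay on membranes from CHO cells for displacement of a labelled ligand from adenosine receptor A1 (Homo sapiens), read by scintillation counting, with a stated time of 60 min, tested at 1 uM (on this read-out lower numbers stand for less inhibition and higher numbers for more inhibition at the one concentration tested (going by the name of the read-out)), compound 1 gives 25% and compound 2 gives 34%; the step of a number 9 percentage points higher from compound 1 to compound 2 (within the scatter) goes with the change (thiophen-2-yl in place of furan-3-yl on a saturated ring carbon). In this assay compound 3 gives 21%. Compound 4 is not yet measured and differs from compound 3 by thiophen-2-yl in place of furan-3-yl on a saturated ring carbon. Within the data shown here, this is the same kind of change as the one between compound 1 and compound 2, not the same: in both cases the exchanged ring sits next to the ring atom that bears a large group, and in the core of compound 3 that group is the 5-methyl-1,3-oxazol-2-yl group (6 heavy atoms). Among the measured compounds shown here, with only one earlier instance, and that one within the scatter, the carried-over size is uncertain. For compound 4 in this assay a step of a number 7 percentage points higher from compound 3 to compound 4 (within the scatter) is expected, resting on a number 9 percentage points higher from compound 1 to compound 2 (within the scatter). Compound 4 is therefore estimated at 28%, with a likely range from 12% to 44%.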

Compound 4, a percentage reported as inhibition, at one concentration (the size of the read-out at that concentration, not a potency): 21%
The estimate for compound 4 lay 7 percentage points above the measured number; the measured number falls inside the stated range.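

In this assay, thiophen-2-yl in place of furan-3-yl on a saturated ring carbon goes with no change at the digits printed from compound 3 to compound 4 (within the scatter). Set beside the earlier instance of this change, the new step does not differ from it: the same change on two cores in this assay, a number 9 percentage points higher (within the scatter) from compound 1 to compound 2 and no change at the digits printed (within the scatter) from compound 3 to compound 4, 9 percentage points apart, within the scatter of two such steps. Among these compounds, the two cores therefore give no sign that the change behaves differently from one to the other, but neither step stands beyond the scatter, so the comparison shows only that the change has no size that can be told apart on either core, not that a real effect of a given size carries over.

The compounds shown leave open whether a different group on that saturated ring carbon, such as an amine or a longer alkyl chain, would give a step beyond the scatter. They also leave open what separate changes to the cores would do, for instance a carboxylic acid in place of the 5-methyl-1,3-oxazol-2-yl group, as no pair shown differs in that place alone.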